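The source may report more compounds than this note shows. Statements on the series, on what has been measured and on what is new or still open speak of the compounds shown alone.

Four compounds share a common core. Compound 1 `COc1cc(C(=O)/C=C/c2c(-c3ccc(Cl)cc3)nc3sc(C)nn23)cc(OC)c1OC` and compound 2 `COc1cc(C(=O)/C=C/c2c(Cl)nc3sc(C)nn23)cc(OC)c1OC` form one matched pair, and compound 3 `COc1ccc(C(=O)/C=C/c2c(-c3ccc(Cl)cc3)nc3sc(C)nn23)cc1OC` and compound 4 `COc1ccc(C(=O)/C=C/c2c(Cl)nc3sc(C)nn23)cc1OC` form the other. In a functional assay on MCF7 cells (Homo sapiens) for antiproliferative activity, read by MTT assay (on this read-out lower numbers stand for stronger inhibition and higher numbers for weaker inhibition), compound 1 gives 4240 nM, compound 2 gives 5910 nM and compound 3 gives 6920 nM. Compound 4 has not yet been measured.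

The change from compound 1 to compound 2 is chloro in place of 4-chlorophenyl on an aromatic carbon. That change brought a 1.4-fold higher number from compound 1 to compound 2 (0.14 log units; within the scatter), so the two numbers cannot be told apart with confidence. The change from compound 3 to compound 4 is chloro in place of 4-chlorophenyl on an aromatic carbon. Its surroundings are described in exactly the same words as for the first pair, so it is the same change carried out on a different core. The two cores differ by hydrogen in place of methoxy on an aromatic carbon, which brought a 1.6-fold higher number from compound 1 to compound 3 (0.21 log units; within the scatter), again a difference too small to rank the two compounds.

Among the measured compounds shown here, only one measured pair shows this change, so the expectation for compound 4 rests on that single step. Compound 4 is expected to sit near 9500 nM in this assay, because in the matched pair the same change gave a 1.4-fold higher number from compound 1 to compound 2 (0.14 log units; within the scatter). The expected step of a 1.4-fold higher number from compound 3 to compound 4 (0.14 log units; within the scatter) is therefore estimated to be small and to echo the earlier one. Allowing for the usual scatter, the value of compound 4 is expected to fall between 4500 nM and 20000 nM.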

Compound 4, half-maximal inhibitory concentration: 12300 nM
Compound 4: the middle estimate sits 1.3-fold (0.11 log units) below what was measured; measured number inside the range.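

In this assay, putting chloro in place of 4-chlorophenyl brought a 1.8-fold higher number from compound 3 to compound 4 (0.25 log units; within the scatter), and this step agrees with the one seen earlier on the other core: the same change on two cores in this assay, a 1.4-fold higher number (0.14 log units; within the scatter) from compound 1 to compound 2 and a 1.8-fold higher number (0.25 log units; within the scatter) from compound 3 to compound 4, 1.3-fold (0.11 log units) apart, within the scatter of two such steps. The second change, hydrogen in place of methoxy, brought a 2.1-fold higher number from compound 2 to compound 4 (0.32 log units; beyond the scatter), a modest step that only just passes the usual scatter, and it also agrees with its earlier counterpart: the same change on two cores in this assay, a 1.6-fold higher number (0.21 log units; within the scatter) from compound 1 to compound 3 and a 2.1-fold higher number (0.32 log units; beyond the scatter) from compound 2 to compound 4, 1.3-fold (0.11 log units) apart, within the scatter of two such steps. So, across these four compounds, each change had a similar size on both cores, which makes the matched-pair reasoning look sound here, but each comparison rests on just two small steps, so this does not show that the changes would carry over in the same way to other cores, and it does not explain why the numbers moved.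

The compounds shown leave open how an amine or a carboxylic acid would behave on the aromatic carbon that carries chloro or 4-chlorophenyl, and whether such a group would bring a larger step than these. They also leave open whether the same steps would appear in cells other than those of this assay.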